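Propoxy in place of chloro on compound 1

The source may hold more compounds than are shown below. What is called first, only, known or untested is meant among the compounds shown, and "the series" means these compounds.

Within the data shown here, in a functional assay on SW620/5-FU cells (Homo sapiens) for cytotoxicity, read by MTT assay, with a stated time of 48 h, in the presence of a further agent that is not named here (on this read-out higher numbers stand for an effect only at larger amounts of compound and lower numbers for an effect already at smaller amounts), compound 1 `COc1ccc(-c2cc(NNC(=O)Nc3cc(Cl)nc(Cl)c3)nc3c2cnn3C)cc1` gives 18500 nM, the higher of the two numbers measured so far, and compound 2 `Cn1ncc2c(-c3ccc(F)cc3)cc(NNC(=O)Nc3cc(Cl)nc(Cl)c3)nc21` gives 9150 nM. Among the measured compounds shown here, the one measured step, a 2.0-fold lower number from compound 1 to compound 2 (0.31 log units; beyond the scatter), comes with fluoro in place of methoxy on an aromatic carbon. Compound 3 `CCCOc1cc(NC(=O)NNc2cc(-c3ccc(OC)cc3)c3cnn(C)c3n2)cc(Cl)n1` keeps the methoxy of compound 1 and instead has propoxy in place of chloro on an aromatic carbon, the 2,6-dichloropyridin-4-yl group becoming 2-chloro-6-propoxypyridin-4-yl: propoxy in place of chloro on an aromatic carbon. For the measured compounds named here, no measured step covers this change, so the step to compound 2 offers only a rough scale and no direction. In this assay no shift beyond the scatter is expected as the central case, although a modest one either way remains possible. The estimated change is a 1.2-fold lower number from compound 1 to compound 3 (0.06 log units; within the scatter). For compound 3 the expected value is 16000 nM, with an estimated range of 5500 nM to 45000 nM.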

Compound 3, half-maximal effective concentration: 37200 nM
Compound 3: middle estimate off by 2.3-fold (0.37 log units), on the low side, within the range that was stated.
By their numbers in this assay, from the lowest: compound 2; then compounds 1 and 3 (each within the scatter of the next).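

In this assay, among these compounds, the chloro next to the ring nitrogen of the 2,6-dichloropyridin-4-yl group has now been changed for the first time, and the step to 2-chloro-6-propoxypyridin-4-yl is a 2.0-fold higher number from compound 1 to compound 3 (0.30 log units; within the scatter) as printed for this pair. The step therefore does not separate propoxy from chloro at this position, even though propoxy brings 4 heavy atoms in place of 1 and adds a hydrogen-bond acceptor. Among the compounds shown here, the only earlier step concerned the fluoro and methoxy exchange elsewhere on the molecule, so this is the first reading at this position, and nothing measured bears on the size of this step.

Still open, going by these compounds, is how an amine such as morpholine, or a longer chain such as butoxy, would read at this position. Also open, on these data alone, is whether propoxy reads the same on the fluoro-bearing compound 2.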